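From Phenyl to 6-Methoxypyridin-3-yl on Compound 1

The source may hold more compounds than are shown below. What is called first, only, known or untested is meant among the compounds shown, and "the series" means these compounds.

In an ADME assay for permeability, using PAMPA, with a stated time of 4 h, at pH 7.4, tested at 100 uM (on this read-out lower numbers stand for lower permeability and higher numbers for higher permeability), compound 1 `Cc1nc2cc(-c3cccc(-c4ccccc4)c3)nn2c(-c2cc(F)c3c(c2C)CCCO3)c1[C@H](OC(C)(C)C)C(=O)O` gives 733 nm/s. Going by the values given here, its only measured neighbour, compound 2 `Cc1nc2cc(-c3cccc(-c4ccccc4)c3)nn2c(-c2cc(F)c3c(c2C)CCCO3)c1C(OC(C)(C)C)C(=O)O`, gives 652 nm/s, and the two values lie within the usual scatter of each other. These compounds share the same atoms and bonds, and what separates them is the fact that one of compounds 1 and 2 is drawn with a defined configuration and the other without, at the place where they differ. The measured step is a 1.1-fold lower number from compound 1 to compound 2 (0.05 log units; within the scatter).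

Compound 3 `COc1ccc(-c2cccc(-c3cc4nc(C)c([C@H](OC(C)(C)C)C(=O)O)c(-c5cc(F)c6c(c5C)CCCO6)n4n3)c2)cn1` keeps the core of compound 1 but exchanges one group: 6-methoxypyridin-3-yl in place of phenyl on an aromatic carbon. In words, 6-methoxypyridin-3-yl stands in place of phenyl on an aromatic carbon. Among the compounds with values here, the one measured step concerns only how a stereocentre is drawn, so it offers no guide to this exchange. Within the data shown here, no measured pair shows what the new group does here, which leaves the value of compound 1, 733 nm/s, as the starting point and calls for a wide range. The expected step is a 1.4-fold lower number from compound 1 to compound 3 (0.15 log units; within the scatter), a modest drop that is not expected to stand clearly beyond the scatter. In this assay, the estimate for compound 3 is 520 nm/s, with an expected range from 260 nm/s to 950 nm/s.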

Compound 3, apparent permeability: 514 nm/s
Estimate against measurement, compound 3: 1.0-fold (0.01 log units) above; measured number inside the range.
By their numbers in this assay, from the lowest: compounds 3, 2 and 1 (each within the scatter of the next).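

In this assay, placing 6-methoxypyridin-3-yl where phenyl stood, on an aromatic carbon meta to a large group, gives a 1.4-fold lower number from compound 1 to compound 3 (0.15 log units; within the scatter). Going by these compounds alone, this is the first measured change to a group at this position, since the earlier step concerned only how a stereocentre is drawn. It shows that a ring of 8 heavy atoms with 2 hydrogen-bond acceptors can replace a carbon-only ring of 6 heavy atoms, with no hydrogen-bond acceptors, while the read-out stays within the usual scatter; the available evidence concerns only the drawing of that stereocentre, so it gives no explanation for this result.

The exchange brings in a ring nitrogen and a methoxy group together, so the compounds shown cannot separate their contributions; a pyridinyl ring without the methoxy group, or a phenyl ring carrying a methoxy group, would address that question. As far as these compounds go, it also remains open whether this position would tolerate an amine, a carboxylic acid or a longer chain in the same way.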